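This account rests on a few compounds, and the source may have more. Where it says the series, first, only, none or still open, it means among the compounds named here.

Measured compounds, each in an assay on membranes from HeLa cells for displacement of a labelled ligand from adenosine receptor A3 (Homo sapiens), read by scintillation counting, with a stated time of 180 min, tested at 1 uM; on this read-out higher numbers stand for more inhibition at the one concentration tested (going by the name of the read-out) and lower numbers for less inhibition:

Compound 1, `CC1=C(C(=O)OC2CCCCC2)C(c2ccoc2)NC(=O)N1`: 1%
Compound 2, `CC1=C(C(=O)OCC2CC2)C(c2ccoc2)NC(=O)N1`: 3%
Compound 3, `CC1=C(C(=O)OC2CCCCC2)C(c2ccsc2)NC(=O)N1`: 1%

Within the data shown here, all three numbers sit close together in this assay, and no compound among them can be set apart from the others. The step of a number 2 percentage points higher from compound 1 to compound 2 (within the scatter) is the change (cyclopropylmethyl in place of cyclohexyl on an oxygen next to a carbonyl group). The step of no change at the digits printed from compound 1 to compound 3 (within the scatter) is the change (thiophen-3-yl in place of furan-3-yl on a saturated ring carbon), which is how the core of compound 3 differs from the core of compound 1.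

Compound 4, `CC1=C(C(=O)OCC2CC2)C(c2ccsc2)NC(=O)N1`, remains to be measured in this assay. It differs from compound 3 by cyclopropylmethyl in place of cyclohexyl on an oxygen next to a carbonyl group. The same change is made from compound 1 to compound 2, and the two place lines read the same word for word, so the change on compound 3 is the same change as on compound 1, carried out on the core of compound 3 instead. Among the measured compounds shown here, the only evidence for its size is the single step from compound 1 to compound 2, which stays within the scatter. Since compound 3 sits level with compound 1, and the change itself moved compound 1 to compound 2 by a step within the scatter, the expected step of a number 2 percentage points higher from compound 3 to compound 4 (within the scatter) is estimated to be of about the same size and to stay within the scatter as well. Compound 4 is accordingly expected to give about 3% in this assay, with the estimate spanning 0% to 10%.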

Compound 4, a percentage reported as inhibition, at one concentration (the size of the read-out at that concentration, not a potency): 3%
Estimate against measurement, compound 4: no gap at the digits printed, within the range that was stated.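

Cyclopropylmethyl in place of cyclohexyl on an oxygen next to a carbonyl group gives, in this assay, a number 2 percentage points higher from compound 3 to compound 4 (within the scatter), and the step reads alike on the core of compound 1 and the core of compound 3: the same change on two cores in this assay, a number 2 percentage points higher (within the scatter) from compound 1 to compound 2 and a number 2 percentage points higher (within the scatter) from compound 3 to compound 4, 0 percentage points apart, within the scatter of two such steps. Thiophen-3-yl in place of furan-3-yl on a saturated ring carbon gives no change at the digits printed from compound 2 to compound 4 (within the scatter), and this step also reads alike with either group on the oxygen: the same change on two cores in this assay, no change at the digits printed (within the scatter) from compound 1 to compound 3 and no change at the digits printed (within the scatter) from compound 2 to compound 4, 0 percentage points apart, within the scatter of two such steps. Among these compounds, the agreement shows only that neither change produces a step beyond the scatter on these cores; as all of these steps lie within the scatter and the read-out reports inhibition at a single concentration rather than a potency, it does not show that a step of real size would carry from one core to another.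

Still open, as far as these compounds go, is whether any replacement at either place gives a step beyond the scatter in this assay, for example a longer chain or a chain bearing an amine on the oxygen, or a phenyl ring on the saturated ring carbon. Also open, from the compounds shown here alone, is whether the two changes would still read alike on a compound with a clearly higher number in this assay.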